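Swapping a cyclic amine for an ether chain on a shared core

A few compounds are considered here, and "the series" means these few. Any claim that something is new, unique, unknown or untested is made for them only; others in the source may bear on it.

Compound 1 `CN(O)C(=O)c1cc2c(CN3CCC(O)C3)cn(Cc3ccc(F)cc3)c2cn1` in an ADME assay on CEM-SS cells (Homo sapiens) for cytotoxicity, read by XTT assay; a higher number here means that more compound is tolerated, a lower number that less compound is tolerated: > 100000 nM, a limit of the assay, not a number.
Compound 2 `CN1CCN(Cc2cn(Cc3ccc(F)cc3)c3cnc(C(=O)N(C)O)cc23)CC1` in this assay: > 224000 nM, likewise a limit of the assay.

For the measured compounds named here, compound 2 therefore stands only at a limit in this assay, and the one other value shown is also a limit. Compound 3 `COCCOCCCc1cn(Cc2ccc(F)cc2)c2cnc(C(=O)N(C)O)cc12` has not yet been measured; it differs from compound 2 by 2-(2-methoxyethoxy)ethyl in place of 4-methylpiperazin-1-yl on a saturated chain carbon bound to an aromatic carbon. Going by the values given here, the only measured step that bears on this place in the molecule is a step that the two limits leave unreadable from compound 1 to compound 2, which the two limits the limit of > 100000 nM in this assay, at which 1 of the 2 values shown sits, and the limit of > 224000 nM in this assay, at which 1 of the 2 values shown sits, leave unreadable in size, so it neither supports nor rules out a change beyond the usual scatter. With no readable step to lean on, compound 3 is expected to sit near where compound 2 stands, and the expected step of an at least 1.1-fold lower number from compound 2 to compound 3 (0.04 log units; that floor lies within the scatter) is small. The estimate for compound 3 is 200000 nM, within 60000 nM to 500000 nM.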

Compound 3, half-maximal cytotoxic concentration: > 10000 nM
Compound 3: a limit, no number (the forecaster's own chance of this, stated with the estimate: 70%); the middle value is on the limit's open side.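

In this assay compound 3 gives > 10000 nM, a limit of the assay and not a number. Its steps from compound 1 and from compound 2 cannot be read in size. The compounds shown leave open whether these three side chains differ at all in how much compound the cells tolerate.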